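Sulfone series: methoxy for chloro on the acyl ring

This account rests on a few compounds, and the source may have more. Where it says the series, first, only, none or still open, it means among the compounds named here.

Measured so far:
compound 1, `CN1CCN(CCCS(=O)(=O)c2ccc3nc(NC(=O)NC(=O)c4cc(-n5cccn5)ccc4Cl)sc3c2)CC1`, a physicochemical assay for lipophilicity (on this read-out lower numbers stand for lower lipophilicity and higher numbers for higher lipophilicity), 2
compound 2, `CN1CCN(CCCS(=O)(=O)c2ccc3nc(NC(=O)NC(=O)c4cc(-n5cccn5)c(Cl)cc4Cl)sc3c2)CC1`, this assay 2.3

Compound 2 carries the extra chloro group and gives the larger of the two numbers; the gap a number 0.30 log units higher from compound 1 to compound 2 (within the scatter) lies within the scatter, so the two compounds cannot be told apart on this read-out. Compound 3, `COc1cc(Cl)c(C(=O)NC(=O)Nc2nc3ccc(S(=O)(=O)CCCN4CCN(C)CC4)cc3s2)cc1-n1cccn1`, is the next member and has not yet been measured in this assay.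

The change is methoxy in place of chloro on an aromatic carbon. Among the measured compounds shown here, the only step at hand, a number 0.30 log units higher from compound 1 to compound 2 (within the scatter), concerns the same carbon: there a chloro group replaced hydrogen and moved the number by an amount inside the scatter. Compound 3 removes that chloro again and puts a methoxy group in its place. For the measured compounds named here, no pair with a methoxy-for-chloro exchange has been measured, so the expectation rests on the small reverse of that one step plus the usual tendency of a methoxy group to read a little lower than chloro in this assay. Compound 3 is therefore expected near 1.9, range 1.5 to 2.3. The expected step of a number 0.40 log units lower from compound 2 to compound 3 (beyond the scatter) would be modest, downward, and possibly still within the scatter.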

Compound 3, distribution coefficient: 2.2
The estimate for compound 3 lay 0.30 log units below the measured number, and the stated range covers the measured number.
By their numbers in this assay, from the lowest: compounds 1, 3 and 2 (each within the scatter of the next).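

In this assay the carbon ortho to a 1H-pyrazol-1-yl group has now carried hydrogen, chloro and methoxy, and methoxy in place of chloro gives a number 0.10 log units lower from compound 2 to compound 3 (within the scatter) and leaves the two compounds indistinguishable on this read-out, even with the additional heavy atom and hydrogen-bond acceptor counted for methoxy. Set against hydrogen on the same carbon, methoxy gives a number 0.20 log units higher from compound 1 to compound 3 (within the scatter) and so adds a second substituent whose step stays inside the scatter, which places all three compounds within the scatter of one another in this assay and leaves this carbon with no readable difference so far. No measurement at hand bears on why these three groups read alike.

From the compounds shown here alone, whether an amine, a carboxylic acid or a longer alkoxy chain on this carbon would produce a step beyond the scatter remains open. Also open, going by these compounds, is whether chloro and methoxy would read alike on the other carbons of this ring, and how the three compounds compare on any other read-out.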